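A few compounds are considered here, and "the series" means these few. Any claim that something is new, unique, unknown or untested is made for them only; others in the source may bear on it.

Notes on the series. Among the measured compounds shown here, in a functional assay for inhibition, with Rattus norvegicus as the target (on this read-out lower numbers stand for stronger inhibition and higher numbers for weaker inhibition), compound 2 `CCCCc1cc(OC)c2ccccc2c1OC(C)=O` gives 440 nM, the lower of the two numbers so far, while compound 1 `CCCCc1c(CC)c(OC)c2ccccc2c1OC(C)=O` gives 990 nM. Compound 3 `CCCCc1ccc2c(OC(C)=O)c(CCCC)cc(OC)c2c1` is the next to be read: butyl in place of hydrogen on an aromatic carbon of the other ring of the fused system. For the measured compounds named here, only one measured step bears on this change: a 2.3-fold lower number from compound 1 to compound 2 (0.35 log units; beyond the scatter), modest and beyond the scatter, with hydrogen in place of ethyl on an aromatic carbon. That step concerns a different aromatic carbon and a shorter chain, so it is a weak guide. With the ethyl present, compound 1 stands higher at 990 nM, so a modest rise in this assay is expected, with wide uncertainty. The expected change is a 1.6-fold higher number from compound 2 to compound 3 (0.20 log units; within the scatter). For compound 3 the estimate is 700 nM, with an expected range of 200 nM to 2500 nM.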

Compound 3, half-maximal inhibitory concentration: 480 nM
The estimate for compound 3 lay 1.5-fold (0.16 log units) above the measured number; low and high end bracket the measured number.
By their numbers in this assay, from the lowest: compounds 2 and 3 (each within the scatter of the next); then compound 1.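

In this assay, butyl in place of hydrogen on this aromatic carbon, meta to a fused ring and para to a fused ring, gives a 1.1-fold higher number from compound 2 to compound 3 (0.04 log units; within the scatter). Among the compounds shown here, this position therefore accepts a chain as large as butyl with no change in the read-out beyond the scatter, whereas the only earlier step, a 2.3-fold lower number from compound 1 to compound 2 (0.35 log units; beyond the scatter), made at a different aromatic carbon, lies beyond the scatter. No measurement at hand offers an explanation for this result.

From the compounds shown here alone, it remains open whether a longer chain such as octyl would also leave the number within the scatter at this aromatic carbon. The effect of an amine or a carboxylic acid at the same place is also open, since butyl is the only group shown there in place of hydrogen.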